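This account rests on a few compounds, and the source may have more. Where it says the series, first, only, none or still open, it means among the compounds named here.

Compound 1 `Fc1ccc(Nc2ncnc3[nH]ccc23)cc1` in an assay on HEK293-TREx cells for antagonist activity at transient receptor potential cation channel subfamily A member 1 (Homo sapiens), read by fluorescence and calcium flux, with a stated time of 72 h; on this read-out higher numbers stand for weaker inhibition and lower numbers for stronger inhibition: compound 1 gives > 32000 nM, a limit of the assay.
Compound 2 `Cc1[nH]c2ncnc(Oc3ccc(F)cc3F)c2c1C`: compound 2 gives 2000 nM.
Compound 3 `CCc1c[nH]c2ncnc(Oc3ccc(F)cc3F)c12`: compound 3 gives 1600 nM.

Among the two compounds with a number, compound 3 and compound 2 give values that lie within the scatter of each other, so neither can be set apart from the other. Compound 1 sits at a limit of > 32000 nM in this assay, at which 1 of the 3 values shown sits, and gives no number.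

Compound 4 `Fc1ccc(Oc2ncnc3[nH]cc(I)c23)c(F)c1` has not yet been measured. It differs from compound 3 by iodo in place of ethyl on an aromatic carbon. Among the compounds with values here, no step of this kind has been measured here, so the size of the change in this assay is open; the expected step from compound 3 to compound 4 is a 1.3-fold lower number from compound 3 to compound 4 (0.12 log units; within the scatter), little beyond the scatter. Compound 4 is estimated at 1200 nM, with a range from 400 nM to 4000 nM.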

Compound 4, half-maximal inhibitory concentration: 2500 nM
Estimate against measurement, compound 4: 2.1-fold (0.32 log units) below; the measured number falls inside the stated range.
By their numbers in this assay, from the lowest: compounds 3, 2 and 4 (each within the scatter of the next). At a limit, above all of these: compound 1.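

In this assay iodo in place of ethyl on this aromatic carbon of the five-membered ring gives a 1.6-fold higher number from compound 3 to compound 4 (0.19 log units; within the scatter) and so shows that one iodine atom can stand at this position in place of a two-carbon chain with no difference that can be told from the scatter. Within the data shown here, this is the first step measured at this position, and it stays within the scatter. Nothing measured here bears on why the two groups read alike.

Going by these compounds, whether an amine, a carboxylic acid or a longer chain at this carbon would move the number beyond the scatter stays open.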